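This account rests on a few compounds, and the source may have more. Where it says the series, first, only, none or still open, it means among the compounds named here.

Compound 1 `Clc1ccc(-n2nncc2-c2cccnc2)cc1`: 27 mg/kg
Compound 2 `Clc1ccc(-n2nncc2-c2ccccn2)cc1`: 50.4 mg/kg
Compound 3 `Brc1ccc(-n2nncc2-c2ccccn2)cc1`: 88.6 mg/kg

In a functional assay on the whole organism with Mus musculus as the target (a lower number here means that less compound is needed, a higher number that more compound is needed for the effect), compound 2 gives the second highest of the three numbers; its nearest neighbour is compound 3 and its furthest is compound 1, and both of those gaps lie within the scatter. Compound 4 `Clc1ccc(-n2nncc2-c2ccccc2)cc1` differs from compound 2 by phenyl in place of pyridin-2-yl on an aromatic carbon. For the measured compounds named here, no measured step removes the ring nitrogen of that group altogether. The step of a 1.9-fold higher number from compound 1 to compound 2 (0.27 log units; within the scatter) shifts the ring nitrogen within the same group, and the step of a 1.8-fold higher number from compound 2 to compound 3 (0.25 log units; within the scatter) concerns the other ring; both lie within the scatter. On that basis no step beyond the scatter is expected from compound 2 to compound 4 in this assay either. In this assay compound 4 is expected to give 50 mg/kg, with a range from 20 mg/kg to 125 mg/kg. The expected step of a 1.0-fold lower number from compound 2 to compound 4 (0.00 log units; within the scatter) thus stays within the scatter.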

Compound 4, dose for half-maximal effect: 95.2 mg/kg
For compound 4 the middle estimate is 1.9-fold (0.28 log units) below the measured one; low and high end bracket the measured number.
By their numbers in this assay, from the lowest: compounds 1, 2, 3 and 4 (each within the scatter of the next, the first and the last beyond it).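

In this assay the group on this aromatic carbon now carries no ring nitrogen, and the data show a 1.9-fold higher number from compound 2 to compound 4 (0.28 log units; within the scatter) when phenyl replaces pyridin-2-yl. For the compounds shown here, they also show a 3.5-fold higher number from compound 1 to compound 4 (0.55 log units; beyond the scatter) when phenyl replaces pyridin-3-yl, so this is the first pair at this position separated beyond the scatter, while pyridin-2-yl stays within the scatter of both. No available evidence accounts for this difference. The compounds shown leave open whether pyridin-4-yl would stand nearer pyridin-3-yl or phenyl. They also leave open how an amine or a carboxylic acid on this carbon would read.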